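Compound 3 to compound 4: a substituent swap

This account rests on a few compounds, and the source may have more. Where it says the series, first, only, none or still open, it means among the compounds named here.

- compound 1 `COc1cc(C(=O)c2cn(-c3ccccc3)cc2-c2ccccc2C)cc(OC)c1OC`: 190 nM
- compound 2 `COc1cc(C(=O)c2cn(-c3ccccc3)cc2-c2cccc(Br)c2)cc(OC)c1OC`: 950 nM
- compound 3 `COc1cc(C(=O)c2cn(-c3ccccc3)cc2-c2ccc([N+](=O)[O-])cc2)cc(OC)c1OC`: 590 nM

All three values come from a functional assay on MCF7 cells (Homo sapiens) for cytotoxicity, read by MTT assay, with a stated time of 96 h; on this read-out lower numbers stand for stronger inhibition and higher numbers for weaker inhibition. Compound 3 gives 590 nM there. Its nearest neighbour is compound 2, with a 1.6-fold lower number from compound 2 to compound 3 (0.21 log units; within the scatter). The step that sets it apart from the best-placed measured value is a 3.1-fold higher number from compound 1 to compound 3 (0.49 log units; beyond the scatter).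

The next compound is compound 4 `COc1ccccc1-c1cn(-c2ccccc2)cc1C(=O)c1cc(OC)c(OC)c(OC)c1`, and the change is 2-methoxyphenyl in place of 4-nitrophenyl on an aromatic carbon. Among the compounds with values here, no measured compound carries 2-methoxyphenyl, so any reading is indirect. The closest comparison is compound 1, which carries 2-methylphenyl at the same place and gives 190 nM. Both measured departures from 2-methylphenyl gave higher numbers, namely a 5.0-fold higher number from compound 1 to compound 2 (0.70 log units; beyond the scatter) and a 3.1-fold higher number from compound 1 to compound 3 (0.49 log units; beyond the scatter). These steps are modest, and the comparison rests on compound 1 alone.

If 2-methoxyphenyl tracks 2-methylphenyl, a modest step to a lower number is expected in this assay. The estimated step is a 2.3-fold lower number from compound 3 to compound 4 (0.36 log units; beyond the scatter). For compound 4 the expected value is 260 nM, with an estimated range of 90 nM to 750 nM.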

Compound 4, half-maximal inhibitory concentration: 190 nM
Compound 4: the middle estimate sits 1.4-fold (0.14 log units) above what was measured, and the stated range covers the measured number.
By their numbers in this assay, from the lowest: compounds 1 and 4 (each within the scatter of the next); then compounds 3 and 2 (each within the scatter of the next).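

In this assay, within the data shown here, methoxy in place of methyl on an aromatic carbon is the first change away from compound 1 that leaves the number in place (no change at the digits printed from compound 1 to compound 4 (within the scatter)), so at this position on the shared core the two groups cannot be told apart. The 2-methoxyphenyl group also separates from both other groups, with a 3.1-fold lower number from compound 3 to compound 4 (0.49 log units; beyond the scatter) and a 5.0-fold lower number from compound 2 to compound 4 (0.70 log units; beyond the scatter), so among these four compounds the 2-methylphenyl and 2-methoxyphenyl groups both give lower numbers than 4-nitrophenyl and 3-bromophenyl, and no compound shown goes against this. No measured evidence at hand accounts for this grouping.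

In the compounds shown, each substituent occurs at only one place on the phenyl ring, so the place of the substituent and its identity remain tied together, and a 4-methoxyphenyl or 3-methylphenyl group would be needed to separate them. On these data alone, it also stays open whether an amine, a chlorine atom or a longer chain such as ethoxy on the same ring would keep to the level of compound 1 and compound 4.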